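Swapping Trifluoromethyl for Chloro on the Ester Series

The source may hold more compounds than are shown below. What is called first, only, known or untested is meant among the compounds shown, and "the series" means these compounds.

Measured so far in a functional assay on the whole organism (blood) with Rattus norvegicus as the target; on this read-out lower numbers stand for an effect already at smaller amounts and higher numbers for an effect only at larger amounts of compound:
Compound 1, `CCOC(=O)C1(CCCc2ccc(Cl)c(Cl)c2)CO1`, gives 330 umol/kg.
Compound 2, `O=C(O)C1(CCCc2cccc(C(F)(F)F)c2)CO1`, gives 80 umol/kg.
Compound 3, `CCOC(=O)C1(CCCc2cccc(C(F)(F)F)c2)CO1`, gives 170 umol/kg.

Compound 3 has the second highest of these three numbers; it sits within the scatter of compound 1 and is separated from compound 2 by a 2.1-fold higher number from compound 2 to compound 3 (0.33 log units; beyond the scatter). Compound 4, `CCOC(=O)C1(CCCc2cccc(Cl)c2)CO1`, is not yet measured. It differs from compound 3 in one place: chloro in place of trifluoromethyl on an aromatic carbon. Among the compounds with values here, no measured step covers this change; the only measured step concerns the ester, not the aromatic ring. Compound 1 carries chloro groups and compound 3 trifluoromethyl, and their values lie within the scatter, but they differ in more than one place. Compound 4 is therefore expected to change little, a step of a 1.2-fold higher number from compound 3 to compound 4 (0.07 log units; within the scatter). Compound 4 is estimated at 200 umol/kg, within 100 umol/kg to 400 umol/kg.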

Compound 4, dose for half-maximal effect: 680 umol/kg
Compound 4: the middle estimate sits 3.4-fold (0.53 log units) below what was measured; the whole stated range lies below it.
By their numbers in this assay, from the lowest: compound 2; then compounds 3 and 1 (each within the scatter of the next); then compound 4.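

In this assay this aromatic carbon turns out to be sensitive to which group it carries: chloro in place of trifluoromethyl brings a 4.0-fold higher number from compound 3 to compound 4 (0.60 log units; beyond the scatter) on the ester series. The two groups therefore cannot be treated as interchangeable here. The chloro that compound 4 lacks also counts, since hydrogen in place of chloro brings a 2.1-fold higher number from compound 1 to compound 4 (0.31 log units; beyond the scatter) even though a chloro remains on the ring.

From the compounds shown here alone, whether a nitrile or a methoxy group at this place would match trifluoromethyl remains open. Nothing available explains either step.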